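Pyridinyl isomer of compound 1: cytotoxicity working notes

The source may hold more compounds than are shown below. What is called first, only, known or untested is meant among the compounds shown, and "the series" means these compounds.

Measured in a functional assay on SMMC-7721 cells (Homo sapiens) for cytotoxicity, read by MTT assay, with a stated time of 24 h; a higher number here means a weaker inhibitor, a lower number a stronger inhibitor:
Compound 1 `O=C1/C(=C/c2cccnc2)CN(S(=O)(=O)c2ccc([N+](=O)[O-])cc2)C/C1=C\c1ccccc1F` gives > 20000 nM (a limit).
Compound 2 `N#Cc1ccc(S(=O)(=O)N2C/C(=C\c3cccnc3)C(=O)/C(=C/c3ccccc3F)C2)cc1` gives 15400 nM.
Compound 3 `CC(=O)Nc1ccc(S(=O)(=O)N2C/C(=C\c3cccnc3)C(=O)/C(=C/c3ccccc3F)C2)cc1` gives 10900 nM.

In this assay compound 1 gives > 20000 nM as a limit and not as a number. Its standing is therefore the limit of > 20000 nM in this assay, at which 1 of the 3 values shown sits, and nothing finer.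

Compound 4 `O=C1/C(=C/c2ccncc2)CN(S(=O)(=O)c2ccc([N+](=O)[O-])cc2)C/C1=C\c1ccccc1F` carries pyridin-4-yl in place of pyridin-3-yl on a double-bonded chain carbon bound to a double-bonded ring carbon, with pyridin-4-yl in place of pyridin-3-yl on a double-bonded chain carbon bound to a double-bonded ring carbon as the counted difference. The two have the same atoms, joined differently.

Among the compounds with values here, no measured step touches this place. All three swap a group on an aromatic carbon, so they guide size only. Cyano in place of nitro gave an at least 1.2-fold lower number from compound 1 to compound 2 (0.11 log units; that floor lies within the scatter) and acetamido in place of nitro gave an at least 1.8-fold lower number from compound 1 to compound 3 (0.26 log units; that floor lies within the scatter) with both floors within the scatter. Acetamido in place of cyano gave a 1.4-fold lower number from compound 2 to compound 3 (0.15 log units; within the scatter) and that too stays within the scatter.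

On that basis the expected step is a number no higher from compound 1 to compound 4 (the limit leaves the size open) in this assay with no direction expected beyond the scatter. The estimate for compound 4 is 20000 nM as the expected value, with an expected range from 9000 nM to 40000 nM and a reading reported only as a limit remains likely.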

Compound 4, half-maximal inhibitory concentration: 15800 nM
Beside the measured number, compound 4's estimate is 1.3-fold (0.10 log units) above it; the range from low to high includes it.
By their numbers in this assay, from the lowest: compounds 3, 2 and 4 (each within the scatter of the next). At a limit, above all of these: compound 1.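

This is the only step shown at this place, as the earlier steps all swap a group on an aromatic carbon: in this assay, pyridin-4-yl in place of pyridin-3-yl on a double-bonded chain carbon bound to a double-bonded ring carbon gives an at least 1.2-fold lower number from compound 1 to compound 4 (0.10 log units; that floor lies within the scatter). The two groups have the same counted features, so the isomer swap changes only how the same atoms are joined, and this change yields a measured number for compound 4 with the nitro group kept. Compound 1 remains a limit, so the step has only a floor and shows no direction beyond the scatter: the limit of > 20000 nM in this assay, at which 1 of the 4 values shown sits.

From the compounds shown here alone, the true size of the step stays open, and so does whether pyridin-4-yl would act the same way with cyano or acetamido in place of nitro. Also open, going by these compounds, is what pyridin-2-yl, a plain phenyl ring or a pyridine ring carrying an amine would give at this place.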